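Hydroxy to methoxy on a compound at the assay limit

The source may hold more compounds than are shown below. What is called first, only, known or untested is meant among the compounds shown, and "the series" means these compounds.

- Compound 1 `CC(=O)Oc1c(O)cc2oc(-c3ccccc3)cc(=O)c2c1O`: 10500 nM
- Compound 2 `CC(=O)Oc1cc2oc(-c3ccccc3)cc(=O)c2c(O)c1OCc1ccccc1`: 16300 nM
- Compound 3 `CCCCCCOc1cc2oc(-c3ccccc3)cc(=O)c2c(O)c1OCCCCCC`: > 100000 nM, a limit

All three compounds were tested in a functional assay on KB cells (Homo sapiens) for inhibition, with a stated time of 72 h; a lower number here means a stronger inhibitor, a higher number a weaker inhibitor. There, compound 1 gives 10500 nM and compound 2 gives 16300 nM, two values within the usual scatter of each other. The entry for compound 3, > 100000 nM, is a limit of the assay and not a number.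

Compound 4 `CCCCCCOc1cc2oc(-c3ccccc3)cc(=O)c2c(OC)c1OCCCCCC` differs from compound 3 in one place: methyl in place of hydrogen on an oxygen on an aromatic ring, which is methyl in place of hydrogen on an oxygen on an aromatic ring, or hydroxy to methoxy. Going by the values given here, no measured pair shows this change, so the data give no direct size for it. Starting from compound 3 at > 100000 nM, no step beyond the scatter is expected in this assay, and a second limit is a likely result. The expected change is a number no higher from compound 3 to compound 4 (the limit leaves the size open), read against a limit rather than a number. For compound 4 the estimated value is 100000 nM, with an expected range from 45000 nM to 200000 nM.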

Compound 4, half-maximal inhibitory concentration: 39100 nM
Estimate against measurement, compound 4: 2.6-fold (0.41 log units) above; the whole stated range lies above it.
By their numbers in this assay, from the lowest: compounds 1 and 2 (each within the scatter of the next); then compound 4. At a limit, above all of these: compound 3.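

In this assay, the change from hydroxy to methoxy on an oxygen on an aromatic ring gives an at least 2.5-fold lower number from compound 3 to compound 4 (0.40 log units; beyond the scatter). Going by these compounds alone, this is the first measured sign that the group on this oxygen matters to the read-out, and it shows that a free hydroxy there is not needed for a measurable value on this core. The step can be given only as a lower bound because its starting point is a limit of the assay, not a number: the limit of > 100000 nM in this assay, at which 1 of the 4 values shown sits.

Within the data shown here, whether the same change would have a similar effect on compound 1 or compound 2 remains open, since only one pair shows it. Also open, as far as these compounds go, is what a longer chain on this oxygen, such as ethyl or butyl, or a chain ending in an amine, would do.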